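Cyclohexyl to hydrogen on the ring nitrogen: cytotoxicity notes

The source may hold more compounds than are shown below. What is called first, only, known or untested is meant among the compounds shown, and "the series" means these compounds.

Measured so far in an ADME assay on MDBK cells (Bos taurus) for cytotoxicity, read by MTT assay, with a stated time of 96 h; on this read-out lower numbers stand for higher toxicity in this test and higher numbers for lower toxicity in this test:
- compound 1 `CCC(=O)Nc1ccc(-c2nc3cc(C(F)(F)F)ccc3n2C2CCCCC2)cc1`: 18000 nM
- compound 3 `CC(=O)Nc1ccc(-c2nc3cc(C(F)(F)F)ccc3n2C2CCCCC2)cc1`: 17000 nM
- compound 2 `CCC(=O)Nc1ccc(-c2nc3cc(C(F)(F)F)ccc3[nH]2)cc1`: the value for compound 2 is a limit of the test, > 100000 nM.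

Compound 1 and compound 3 share a core and differ only by hydrogen in place of methyl on a saturated chain carbon bound to a carbonyl carbon; the step of a 1.1-fold lower number from compound 1 to compound 3 (0.02 log units; within the scatter) is within the scatter, so the two read alike in this assay. Compound 1 and compound 2 differ by hydrogen in place of cyclohexyl on an aromatic nitrogen; the step of an at least 5.5-fold higher number from compound 1 to compound 2 (0.74 log units; beyond the scatter), its size open at the top because of the limit of > 100000 nM in this assay, at which 1 of the 3 values shown sits.

Compound 4 `CC(=O)Nc1ccc(-c2nc3cc(C(F)(F)F)ccc3[nH]2)cc1` is not yet measured. It differs from compound 3 by hydrogen in place of cyclohexyl on an aromatic nitrogen, the same change as that from compound 1 to compound 2, at the same place. Because compound 3 sits where compound 1 sits (a 1.1-fold lower number from compound 1 to compound 3 (0.02 log units; within the scatter)), a step of a 5.9-fold higher number from compound 3 to compound 4 (0.77 log units; beyond the scatter) of at least the earlier size is expected. Compound 4 is therefore estimated at 100000 nM, between 40000 nM and 300000 nM, with a fair chance that only a limit is reported.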

Compound 4, half-maximal cytotoxic concentration: 50000 nM
Beside the measured number, compound 4's estimate is 2.0-fold (0.30 log units) above it, and the stated range covers the measured number.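

In this assay, hydrogen in place of cyclohexyl on the aromatic nitrogen gives a 2.9-fold higher number from compound 3 to compound 4 (0.47 log units; beyond the scatter), which agrees in direction with the earlier step, and both steps lie beyond the scatter: the same change on two cores in this assay, an at least 5.5-fold higher number (0.74 log units; beyond the scatter) from compound 1 to compound 2 and a 2.9-fold higher number (0.47 log units; beyond the scatter) from compound 3 to compound 4; the limit leaves it open whether they differ. Hydrogen in place of methyl on the chain carbon bound to the carbonyl carbon gives an at least 2.0-fold lower number from compound 2 to compound 4 (0.30 log units; that floor lies within the scatter), which is only a floor, so this pair does not show whether that change carries over: the same change on two cores in this assay, a 1.1-fold lower number (0.02 log units; within the scatter) from compound 1 to compound 3 and an at least 2.0-fold lower number (0.30 log units; that floor lies within the scatter) from compound 2 to compound 4; the limit leaves it open whether they differ. Compound 2 gives > 100000 nM, which is a limit, so the notes show that the direction of the cyclohexyl change carries across these two cores but not that its size does: the limit of > 100000 nM in this assay, at which 1 of the 4 values shown sits.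

The compounds shown leave open how a methyl or a phenyl group on the aromatic nitrogen would read against cyclohexyl and hydrogen. They also leave open how a longer chain or an amine on the carbonyl carbon would read on either core.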